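The source may hold more compounds than are shown below. What is called first, only, known or untested is meant among the compounds shown, and "the series" means these compounds.

Measured so far:
compound 1, `COc1ccc(/C=N/c2ccc(OC(=O)C(C)c3ccc(CC(C)C)cc3)cc2)cc1` — 64.7%
compound 2, `CC(C)Cc1ccc(C(C)C(=O)Oc2ccc(/N=C/c3ccc([N+](=O)[O-])cc3)cc2)cc1` — 53.8%

Both were tested in a functional assay on the whole organism (strain Wistar CF) for inhibition, with Rattus norvegicus as the target, read by paw edema, with stated times of 1 h and 4 h, at a dose of 100 mg/kg by the oral route; on this read-out lower numbers stand for less inhibition and higher numbers for more inhibition at the one dose given (going by the name of the read-out). On the two numbers shown, compound 2 stands lowest; compound 1 is the only other compound, and the one measured step, a number 10.9 percentage points lower from compound 1 to compound 2 (beyond the scatter), separates them. Compound 3, `CC(C)Cc1ccc(C(C)C(=O)Oc2ccc(/N=C/c3ccc(N(C)C)cc3)cc2)cc1`, is not yet measured. It differs from compound 2 in one place: dimethylamino in place of nitro on an aromatic carbon.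

Among the measured compounds shown here, the single measured step bears on this only loosely: it replaced methoxy with nitro and lowered the read-out, while the present change removes that same nitro and puts in dimethylamino. For the measured compounds named here, no step with dimethylamino itself has been measured. Since the nitro compound is the lower of the two, removing the nitro is expected to bring the number back up by a modest amount, roughly a number 8.2 percentage points higher from compound 2 to compound 3 (within the scatter). Compound 3 is therefore estimated at 62%, with a range from 50% to 74%.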

Compound 3, a percentage reported as inhibition, in the whole organism at one dose (the size of the read-out at that dose, not a potency): 107%
The estimate for compound 3 lay 45 percentage points below the measured number; the whole stated range lies below it.
By their numbers in this assay, from the lowest: compound 2; then compound 1; then compound 3.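

Dimethylamino on this aromatic carbon, para to a large group, changes the paw-swelling result in this assay far more than the earlier swap of nitro for methoxy did (a number 10.9 percentage points lower from compound 1 to compound 2 (beyond the scatter)). It stands well clear of both other groups, whether it replaces nitro (a number 53.2 percentage points higher from compound 2 to compound 3 (beyond the scatter)) or methoxy (a number 42.3 percentage points higher from compound 1 to compound 3 (beyond the scatter)), so the choice of group at this position can produce a large difference, not only a modest one. Nothing available explains why dimethylamino stands out in this way.

On these data alone, it remains open whether the gain is specific to dimethylamino or is shared by a primary amine, diethylamino or pyrrolidine at the same place. Among the compounds shown here, with only the one dose given, these compounds also leave open how the inhibition would change at lower doses.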